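The compounds below may be only part of what the source reports. "The series", "measured", "known", "first", "only" and "open" are said of these compounds alone.

Measured in a functional assay on L5178Y cells (Mus musculus) for inhibition, read by MTT assay, with a stated time of 72 h; a higher number here means a weaker inhibitor, a lower number a stronger inhibitor:
Compound 1 `C[Se]C(=O)c1ccc(C(=O)[Se]C)s1`: > 100000 nM
Compound 2 `COC(=O)C[Se]C(=O)c1ccc(Cl)cc1`: > 100000 nM
Compound 3 `O=C(C[Se]C(=O)c1ccccc1)Oc1ccccc1`: > 100000 nM

Compound 2 stands at > 100000 nM, which is a limit of the assay and not a number. Among the compounds with values here, the whole series so far sits at one value, (the limit of > 100000 nM in this assay, at which 3 of the 3 values shown sit), so no measured step is available for sizing a change.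

Compound 4 `CC(C)(C)C(=O)C[Se]C(=O)c1ccc(Cl)cc1` carries tert-butyl in place of methoxy on a carbonyl carbon. In this assay, a shift toward stronger inhibition is expected, of uncertain size, and compound 4 may also remain at the limit. The expected shift is an at least 33-fold lower number from compound 2 to compound 4 (1.52 log units; beyond the scatter). Compound 4 is estimated at 3000 nM, with an expected range from 300 nM to 50000 nM.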

Compound 4, half-maximal inhibitory concentration: 940 nM
For compound 4 the middle estimate is 3.2-fold (0.50 log units) above the measured one, within the range that was stated.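

In this assay, tert-butyl in place of methoxy on a carbonyl carbon gives an at least 100-fold lower number from compound 2 to compound 4 (2.02 log units; beyond the scatter). This shows that a change at this position can bring the series off the single value shared by the earlier compounds: the limit of > 100000 nM in this assay, at which 3 of the 4 values shown sit.

From the compounds shown here alone, compound 2 stands at > 100000 nM, which is a limit of the assay and not a number, so the full size of the step stays unknown.

Going by these compounds, it remains open whether tert-butyl itself matters or any carbon group at this place would do. Methyl, phenyl and an amine at this carbonyl carbon are not among the compounds shown.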